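The compounds below may be only part of what the source reports. "The series", "measured", "known", "first", "only" and "open" are said of these compounds alone.

Measured in a functional assay on L02 cells (Homo sapiens) for inhibition, read by Griess assay, with stated times of 1 h and 24 h; on this read-out lower numbers stand for stronger inhibition and higher numbers for weaker inhibition:
- Compound 1 `C(=C/c1nc(Nc2ccccc2)c2sccc2n1)\c1ccccc1`: > 1000000 nM
- Compound 2 `Fc1ccc(CNc2nc(/C=C/c3ccccc3)nc3ccsc23)cc1`: > 1000000 nM

In this assay compound 2 gives > 1000000 nM, which is a limit and not a number. Compound 1 gives > 1000000 nM, which is also a limit. Compound 2 therefore stands at the limit of > 1000000 nM in this assay, at which 2 of the 2 values shown sit.

Compound 3 `Clc1ccccc1CNc1nc(/C=C/c2ccccc2)nc2ccsc12` keeps the shared core of compound 2 and differs in one place: 2-chlorophenyl in place of 4-fluorophenyl on a saturated chain carbon bound to a nitrogen on an aromatic ring. In words, 2-chlorophenyl replaces 4-fluorophenyl on a saturated chain carbon bound to a nitrogen on an aromatic ring.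

Among the measured compounds shown here, only one measured step bears on this change: a step that the two limits leave unreadable from compound 1 to compound 2. It offers no size to carry forward, so no direction can be expected in this assay and no step beyond the scatter is expected.

The expected change is a number no higher from compound 2 to compound 3 (the limit leaves the size open).

The estimated value for compound 3 is 1000000 nM, with an expected range of 300000 nM to 2000000 nM, and another limit is the likeliest report.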

Compound 3, half-maximal inhibitory concentration: > 1000000 nM
Compound 3 gave a limit, no number; the forecaster's own chance of this, stated with the estimate: 75%; the middle value lies on the limit itself.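

In this assay compound 3 gives > 1000000 nM, which is a limit and not a number. No step among compound 1, compound 2 and compound 3 can be read, because all three sit at the same limit: the limit of > 1000000 nM in this assay, at which 3 of the 3 values shown sit.

The compounds shown leave open whether swapping these groups changes inhibition at all.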